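Amide Aryl Swap on a Shared Core: Pyrazinyl to Methoxypyridinyl

The compounds below may be only part of what the source reports. "The series", "measured", "known", "first", "only" and "open" are said of these compounds alone.

Measured compounds:
compound 1, `Nc1ccc(NC(=O)c2c(O)c3cccnc3n(-c3ccccc3)c2=O)cc1`, 0%
compound 2, `O=C(Nc1cnccn1)c1c(O)c2cccnc2n(-c2ccccc2)c1=O`, 21.2%

Of the compounds shown here, two sharing one core have been tested in a functional assay on the whole organism for inhibition, with Rattus norvegicus as the target, read by cytopathic effect and paw edema, at a dose of 100 mg/kg by the oral route; on this read-out higher numbers stand for more inhibition at the one dose given (going by the name of the read-out) and lower numbers for less inhibition. Compound 1 gives 0% and compound 2 gives 21.2%. Compound 2 thus stands highest of the two numbers, and its nearest neighbour, compound 1, sits a step below it: a number 21.2 percentage points higher from compound 1 to compound 2 (beyond the scatter).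

The new compound 3, `COc1ccc(NC(=O)c2c(O)c3cccnc3n(-c3ccccc3)c2=O)cn1`, differs from compound 2 in one place: 6-methoxypyridin-3-yl in place of pyrazin-2-yl on an amide-type nitrogen.

Among the measured compounds shown here, only one measured step bears on this change, and only loosely: a number 21.2 percentage points higher from compound 1 to compound 2 (beyond the scatter) shows that exchanging the aryl group on the amide-type nitrogen can move this read-out by a modest, real amount. For the measured compounds named here, no step compares two six-membered aromatic rings with one hetero atom against two hetero atoms at this position, so the direction is open. The account therefore expects a small step, most likely downward or none beyond the scatter, a number 6.2 percentage points lower from compound 2 to compound 3 (within the scatter).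

Compound 3 is estimated to give 15%, within a range from 0% to 40%.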

Compound 3, a percentage reported as inhibition, in the whole organism at one dose (the size of the read-out at that dose, not a potency): -10.2%
Compound 3: the middle estimate sits 25.2 percentage points above what was measured, outside the stated range (below it).
By their numbers in this assay, from the lowest: compound 3; then compound 1; then compound 2.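

On this position the aryl group can do more than the first step showed: 6-methoxypyridin-3-yl in place of pyrazin-2-yl on the amide-type nitrogen in this assay gives a number 31.4 percentage points lower from compound 2 to compound 3 (beyond the scatter), a large step where the earlier one was modest. The new group also falls short of 4-aminophenyl, with a number 10.2 percentage points lower from compound 1 to compound 3 (beyond the scatter), so among these three amides pyrazin-2-yl alone stands clear of the other two, and compound 3 , at -10.2%, takes the lowest place. Nothing measured here accounts for this fall, and the change of ring and the added methoxy cannot be told apart from these numbers, as they enter together.

The compounds shown leave open which of the two matters, a question that a plain pyridin-3-yl or a 5-methoxypyrazin-2-yl on the same amide-type nitrogen would address. Going by these compounds, they also leave open whether a longer alkoxy chain or an amine in place of the methoxy on the pyridine ring would hold the read-out as low, and since each number comes from one oral dose, how these amides compare at other doses remains open too.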